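Swapping a Furan Ring for an Isopropylsulfanyl Chain

The source may report more compounds than this note shows. Statements on the series, on what has been measured and on what is new or still open speak of the compounds shown alone.

Compound 1, `Cc1cc(F)c(S(C)(=O)=O)cc1C(=O)N=C(N)N`, gives 44 nM in a functional assay for inhibition of sodium/hydrogen exchanger (Oryctolagus cuniculus); a lower number here means a stronger inhibitor, a higher number a weaker inhibitor.
Compound 2, `Cc1cc(-c2cc(Cl)cc(Cl)c2)c(S(C)(=O)=O)cc1C(=O)N=C(N)N`, gives 130 nM in this assay.
Compound 3, `Cc1cc(-c2ccco2)c(S(C)(=O)=O)cc1C(=O)N=C(N)N`, gives 16 nM in this assay.

The three compounds share one core and differ only in the group on one aromatic carbon. Compound 3 stands lowest of the three numbers, and both a 2.8-fold lower number from compound 1 to compound 3 (0.44 log units; beyond the scatter) and an 8.1-fold lower number from compound 2 to compound 3 (0.91 log units; beyond the scatter) lie beyond the scatter, so it is the strongest inhibitor measured here. The other step at this position, a 3.0-fold higher number from compound 1 to compound 2 (0.47 log units; beyond the scatter), went the opposite way.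

Compound 4, `Cc1cc(SC(C)C)c(S(C)(=O)=O)cc1C(=O)N=C(N)N`, has not been measured. The change is isopropylsulfanyl in place of furan-2-yl on an aromatic carbon. Among the compounds with values here, none of the measured steps puts a chain without a ring at this position, so no step bears on it directly. What the steps show is that this position matters: the small fluoro group of compound 1 sits between the two ring groups of compound 2 and compound 3. An isopropylsulfanyl chain is expected to land in that middle region, giving a 2.5-fold higher number from compound 3 to compound 4 (0.40 log units; beyond the scatter) in this assay. The estimate for compound 4 is therefore 40 nM, with a range from 12 nM to 130 nM.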

Compound 4, half-maximal inhibitory concentration: 12 nM
Compound 4: the middle estimate sits 3.3-fold (0.52 log units) above what was measured; measured number inside the range.
By their numbers in this assay, from the lowest: compounds 4 and 3 (each within the scatter of the next); then compound 1; then compound 2.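

Compound 4 shows that this position does not need a ring to reach the low end of the series, since the change from a furan-2-yl ring to an isopropylsulfanyl chain gives a 1.3-fold lower number from compound 3 to compound 4 (0.12 log units; within the scatter) in this assay. The chain also stands clearly apart from the other two groups, with a 3.7-fold lower number from compound 1 to compound 4 (0.56 log units; beyond the scatter) and the large 11-fold lower number from compound 2 to compound 4 (1.03 log units; beyond the scatter), so among these compounds a ring is neither required, as compound 4 shows, nor enough by itself, as the 3,5-dichlorophenyl ring of compound 2 shows. Nothing measured here explains how two such different groups come to have numbers within the scatter of each other.

As far as these compounds go, it remains open whether the sulfur atom of the chain matters, and an isopropoxy group, with oxygen in its place, or a plain isopropyl group would test that. Also open, from the compounds shown here alone, is how far this tolerance for a chain extends at this position, for example to a longer chain such as n-butylsulfanyl or to an amine.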